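This account rests on a few compounds, and the source may have more. Where it says the series, first, only, none or still open, it means among the compounds named here.

Three compounds sharing one core have been examined so far in a physicochemical assay for solubility; on this read-out higher numbers stand for higher solubility and lower numbers for lower solubility. In this read-out compound 1 `CS(=O)(=O)c1ccc(-n2nc(C(F)(F)F)cc2-c2ccccc2)nc1` gives 50 ug/mL, and compound 2 `C[C@@H]1CN(c2cc(C(F)(F)F)nn2-c2ccc(S(C)(=O)=O)cn2)[C@H](C)CO1` gives 100 ug/mL. Compound 3 `CC(C)(C)CNc1cc(C(F)(F)F)nn1-c1ccc(S(C)(=O)=O)cn1` has no number to stand on: its entry in this assay reads "not determined" (no result reported). Within the data shown here, no step can therefore be drawn from it, and its place relative to the other two is unknown.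

The next compound, compound 4 `CS(=O)(=O)c1ccc(-n2nc(C(F)(F)F)cc2OCC2CCC2)nc1`, is compound 3 with cyclobutylmethoxy in place of neopentylamino on an aromatic carbon. Among the measured compounds shown here, the only measured step that bears on this is another exchange of groups on an aromatic carbon, a 2.0-fold higher number from compound 1 to compound 2 (0.30 log units; within the scatter). That step lies within the scatter, and it involves different groups, so it offers only weak guidance. With no measured starting point in compound 3, no step size can be expected for this change, and no direction can be assigned to it. The expectation instead rests on the values of compound 1 at 50 ug/mL and compound 2 at 100 ug/mL, with a wide margin for the new group. For compound 4 the estimated value in this assay is 50 ug/mL, with an expected range from 15 ug/mL to 150 ug/mL.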

Compound 4, solubility: 100 ug/mL
The estimate for compound 4 lay 2.0-fold (0.30 log units) below the measured number; low and high end bracket the measured number.
By their numbers in this assay, from the lowest: compounds 1, 2 and 4 (each within the scatter of the next).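

In this assay this aromatic carbon now has three groups with a number, and the new one can be read against both earlier compounds: the step to cyclobutylmethoxy shows no change at the digits printed from compound 2 to compound 4 (within the scatter), and the step from phenyl shows a 2.0-fold higher number from compound 1 to compound 4 (0.30 log units; within the scatter). With both steps within the scatter, phenyl, cyclobutylmethoxy and the six-membered non-aromatic ring with 2 hetero atoms cannot be told apart on this read-out at this position, so among compounds 1, 2 and 4 neither the change of ring nor the oxygen link separates the values. Nothing measured here explains why these groups read alike.

The step from compound 3 to compound 4 cannot be read, since compound 3 has no number, and so the place of neopentylamino among these groups stays unknown. Also open, as far as these compounds go, is whether a group of another kind on this carbon, such as a carboxylic acid or a primary amine on a longer chain, would move the number beyond the scatter, or whether the values would stay as close as they do for these three compounds.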